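The source may report more compounds than this note shows. Statements on the series, on what has been measured and on what is new or still open speak of the compounds shown alone.

In a functional assay on LM7 cells (Homo sapiens) for cytotoxicity, read by MTT assay, with a stated time of 72 h (a lower number here means a stronger inhibitor, a higher number a weaker inhibitor), three compounds sharing a core have been measured. Compound 1 `Cc1cc(C)nc(SCc2cc(=O)c3cc(Cl)ccc3o2)n1` reaches only a limit of the assay, > 25000 nM. Compound 3 `Cc1ccc2oc(CSc3nc(C)cc(C)n3)cc(=O)c2c1` likewise stops at a limit, > 25000 nM. The change between them is methyl in place of chloro on an aromatic carbon, and the resulting step that the two limits leave unreadable from compound 1 to compound 3 cannot be sized, which follows from the limit of > 25000 nM in this assay, at which 3 of the 3 values shown sit. Compound 2 `O=c1cc(CSc2nc3ccccc3s2)oc2ccc(Cl)cc12` also gives only a limit, > 25000 nM. How the core of compound 2 differs from that of compound 1 is not broken down here.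

Compound 4 `Cc1ccc2oc(CSc3nc4ccccc4s3)cc(=O)c2c1` has not yet been measured in this assay. For the measured compounds named here, it differs from compound 2 by methyl in place of chloro on an aromatic carbon, the same change as the one from compound 1 to compound 3, at the same place. The measured step offers no readable size to carry over, and every value seen so far sits at a limit. The expected step is therefore a step that the limit leaves unreadable from compound 2 to compound 4. The estimate for compound 4 is 40000 nM, expected to fall between 15000 nM and 100000 nM, most likely again reported only as a limit.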

Compound 4, half-maximal inhibitory concentration: > 25000 nM
Compound 4: a limit, no number; the forecaster's own chance of this, stated with the estimate: 85%; the middle value lies beyond the limit too.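

No size can be read for the step from compound 2 to compound 4, where methyl replaces chloro, because both compounds give only a limit: the limit of > 25000 nM in this assay, at which 4 of the 4 values shown sit. The compounds shown leave open how chloro and methyl compare in this assay, and whether any compound sharing these cores would give a measurable number there.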